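Halogen Placement on the Anilide Ring and Liver-Cell Tolerance

A few compounds are considered here, and "the series" means these few. Any claim that something is new, unique, unknown or untested is made for them only; others in the source may bear on it.

Compound 1 `COc1ccc2nc(C)cc(OCC(=O)Nc3cccc(Br)c3)c2c1` was tested in an ADME assay on HepG2 cells (Homo sapiens) for cytotoxicity, read by trypan blue exclusion, with a stated time of 48 h, in the presence of a further agent that is not named here; a lower number here means that less compound is tolerated, a higher number that more compound is tolerated. In this assay compound 1 gives > 125000 nM, which is a limit of the assay rather than a measured number. Compound 2 `COc1ccc2nc(C)cc(OCC(=O)Nc3ccc(Br)cc3)c2c1` likewise gives > 125000 nM in this assay, again a limit. The step that the two limits leave unreadable from compound 1 to compound 2 cannot be sized because of the limit of > 125000 nM in this assay, at which 2 of the 2 values shown sit. Compound 3 `COc1ccc2nc(C)cc(OCC(=O)Nc3ccccc3Cl)c2c1` differs from compound 2 by 2-chlorophenyl in place of 4-bromophenyl on an amide-type nitrogen. Among the measured compounds shown here, no measured step bears on such a change, so no shift beyond the scatter is expected and the expected step is a step that the limit leaves unreadable from compound 2 to compound 3. Compound 3 is estimated at 150000 nM, within 100000 nM to 300000 nM, most likely again reported only as a limit.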

Compound 3, half-maximal cytotoxic concentration: > 140000 nM
Compound 3 was reported as a limit; the forecaster's own chance of this, stated with the estimate: 85%; the middle value does not contradict the limit.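

Among the compounds shown here, the results for compound 1, compound 2 and compound 3 in this assay are all limits of the assay, and no step among them can be read. The compounds shown leave open at what concentration each becomes cytotoxic, and whether the halogen or its placement changes that concentration.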